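Fluorine on the phenyl ring and liver microsome stability

The source may hold more compounds than are shown below. What is called first, only, known or untested is meant among the compounds shown, and "the series" means these compounds.

Measured compounds:
Compound 1 `Cc1onc(-c2ccccc2)c1[C@@H]1C[C@@](C)(c2ccc(F)cc2F)N=C(N)S1`: 38%
Compound 2 `Cc1onc(-c2ccc(F)cc2)c1[C@@H]1C[C@@](C)(c2ccc(F)cc2F)N=C(N)S1`: 24%
Compound 3 `Cc1noc(-c2ccccc2)c1[C@@H]1C[C@@](C)(c2ccc(F)cc2F)N=C(N)S1`: 39%

The three measured compounds were tested in an ADME assay on microsomes from liver (Homo sapiens) for metabolic stability, with a stated time of 10 min, tested at 0.5 uM; a lower number here means that less of the compound is left, a higher number that more of the compound is left. In this assay compound 1 gives 38%, compound 2 gives 24% and compound 3 gives 39%. The values of compound 1 and compound 3 lie within the usual scatter of each other, so nothing can be said about an order between them; only compound 2 stands apart, with a value beyond the scatter from both.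

Compound 1 and compound 3 share the same atoms joined differently; the difference between the two cores is not broken down here. From compound 1 to compound 2 one change is made: fluoro in place of hydrogen on an aromatic carbon. This gave a number 14 percentage points lower from compound 1 to compound 2 (beyond the scatter).

Compound 4 `Cc1noc(-c2ccc(F)cc2)c1[C@@H]1C[C@@](C)(c2ccc(F)cc2F)N=C(N)S1` has not yet been measured. It stands to compound 3 exactly as compound 2 stands to compound 1, and the change is the same: fluoro in place of hydrogen on an aromatic carbon. Among the compounds with values here, since the surroundings of the changed place read the same in both pairs, the single earlier step is the only guide. On that basis the expected step is a number 14 percentage points lower from compound 3 to compound 4 (beyond the scatter) in this assay, resting on compound 1 and compound 2 having shown a number 14 percentage points lower from compound 1 to compound 2 (beyond the scatter). Compound 4 is therefore estimated to give 25%, with a plausible range from 12% to 38%.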

Compound 4, percent of the compound remaining: 45%
For compound 4 the middle estimate is 20 percentage points below the measured one; measured number above the stated range.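

In this assay, the change from phenyl to 4-fluorophenyl on the core of compound 3 gave a number 6 percentage points higher from compound 3 to compound 4 (within the scatter), so on this core the step cannot be told apart from repeat-to-repeat variation. The same swap therefore did not behave alike on the two cores, and the result on one core was a poor guide to the result on the other: the same change on two cores in this assay, a number 14 percentage points lower (beyond the scatter) from compound 1 to compound 2 and a number 6 percentage points higher (within the scatter) from compound 3 to compound 4, 20 percentage points apart, beyond the scatter of two such steps

Within the data shown here, this shows that, in this small series, the effect of this fluoro on the share of compound left depends on the core that carries it, so it cannot simply be carried across as a fixed step; it does not show why the two cores differ, nor that fluoro raises the number on the core of compound 3, and with only one pair on each core it says nothing about how the change would read on any further core.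

The compounds shown leave open how a chloro, a methoxy or a nitrile in the same place would read on each of the two cores. They also leave open whether a group of that kind would separate the two cores as clearly as fluoro does, or would give similar steps on both.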